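Trifluoromethyl for cyano on a bridged nicotinic scaffold

The source may hold more compounds than are shown below. What is called first, only, known or untested is meant among the compounds shown, and "the series" means these compounds.

Compound 1 `N#Cc1ccc2c(c1)C1CNCC2C1` carries a cyano group on the aromatic ring of its core and, in an assay on HEK293 cells for binding affinity to Neuronal acetylcholine receptor; alpha4/beta2 (Homo sapiens) (a lower number here means a stronger inhibitor, a higher number a weaker inhibitor), compound 1 gives 0.5 nM. Two other compounds share the same bicyclic amine framework. Compound 2 `Cc1nc2cc3c(cc2[nH]1)C1CNCC3C1` gives 0.1 nM, and compound 3 `Cc1nc2cc3c(cc2nc1C)C1CNCC3C1` gives 0.55 nM. Among these three numbers compound 1 stands second highest: its value sits within the usual scatter of that of compound 3, while its value lies beyond the scatter above that of compound 2.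

Compound 4 `FC(F)(F)c1ccc2c(c1)C1CNCC2C1` has not yet been measured. It differs from compound 1 in a single place: trifluoromethyl in place of cyano on an aromatic carbon. Among the compounds with values here, the cyano group brings one hydrogen-bond acceptor, the trifluoromethyl group brings none, and no measured pair of compounds shows this exchange, so its consequence cannot be read off directly.

The step from compound 1 to compound 4 is expected to go toward a higher number, likely beyond the scatter, so that in this assay compound 4 is estimated at 4 nM, within a range of 1 nM to 20 nM. The expected size of that change is an 8.0-fold higher number from compound 1 to compound 4 (0.90 log units; beyond the scatter).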

Compound 4, inhibition constant: 0.33 nM
Beside the measured number, compound 4's estimate is 12-fold (1.08 log units) above it; the measured number lies below the stated range.
By their numbers in this assay, from the lowest: compound 2; then compounds 4, 1 and 3 (each within the scatter of the next).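

Replacing cyano with trifluoromethyl on this aromatic carbon, which is meta to a fused ring and para to a fused ring, gives a 1.5-fold lower number from compound 1 to compound 4 (0.18 log units; within the scatter) in this assay. The earlier compounds shown here held no pair with this exchange, and this step shows that, on the core of compound 1, the number stays within the scatter even though the hydrogen-bond acceptor and the triple bond of the cyano group leave and the heavy-atom count of the group goes from 2 to 4. No measurement at hand bears on why the two groups give such similar numbers.

The compounds shown leave open whether other groups on the same aromatic carbon, such as an amine, a methoxy group, a carboxylic acid or a primary amide, would also stay within the scatter of compound 1, so the limits of what this position accepts remain unknown. They also leave open whether trifluoromethyl and cyano would give such similar numbers at another aromatic carbon of the shared core, or in any assay on another receptor.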